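The compounds below may be only part of what the source reports. "The series", "measured", "known", "first", "only" and "open" are said of these compounds alone.

Measured compounds:
compound 1 `Cc1cc(O)c(C2=NN(c3ccc(S(N)(=O)=O)cc3)C(c3ccccc3O)C2)cc1Cl`, in a functional assay on SF-295 cells (Homo sapiens) for antiproliferative activity, with a stated time of 48 h (on this read-out lower numbers stand for stronger inhibition of growth and higher numbers for weaker inhibition of growth), compound 1 gives 1660 nM
compound 2 `Cc1cc(O)c(C2=NN(c3ccc(S(N)(=O)=O)cc3)C(/C=C/c3ccccc3)C2)cc1Cl`, in this assay compound 2 gives 2360 nM

Within the data shown here, compound 2 shows the highest of the two numbers, yet its only neighbour, compound 1, sits a 1.4-fold higher number from compound 1 to compound 2 (0.15 log units; within the scatter). Compound 3 `COc1ccc(C2CC(c3cc(Cl)c(C)cc3O)=NN2c2ccc(S(N)(=O)=O)cc2)cc1OC` differs from compound 2 in one place: 3,4-dimethoxyphenyl in place of 2-phenylethenyl on a saturated ring carbon. Among the measured compounds shown here, the single measured step at that saturated ring carbon bears on it, and it stayed within the scatter, so no move beyond the scatter is expected in this assay, the step of a 1.3-fold lower number from compound 2 to compound 3 (0.12 log units; within the scatter) being the estimate. Compound 3 is therefore expected to give about 1800 nM, between 700 nM and 4500 nM.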

Compound 3, concentration for 50% growth inhibition: 2700 nM
Beside the measured number, compound 3's estimate is 1.5-fold (0.18 log units) below it; measured number inside the range.
By their numbers in this assay, from the lowest: compounds 1, 2 and 3 (each within the scatter of the next).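

At the saturated ring carbon, 3,4-dimethoxyphenyl also stays within the scatter of the two earlier groups in this assay: the replacement of 2-phenylethenyl gives a 1.1-fold higher number from compound 2 to compound 3 (0.06 log units; within the scatter) and the replacement of 2-hydroxyphenyl gives a 1.6-fold higher number from compound 1 to compound 3 (0.21 log units; within the scatter). The three groups at this position therefore cannot be ranked on this read-out. No supporting evidence bears on this result. The compounds shown leave open whether a group of another kind on this carbon, such as an amine or a carboxylic acid, would move the number beyond the scatter.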